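Cytotoxicity notes: methanesulfonamido in place of fluoro

The compounds below may be only part of what the source reports. "The series", "measured", "known", "first", "only" and "open" are said of these compounds alone.

Measured compounds in an ADME assay on CHO cells (Cricetulus griseus) for cytotoxicity, read by MTT assay; on this read-out higher numbers stand for weaker inhibition and lower numbers for stronger inhibition:
compound 1 `Cc1cc(C)n(-c2nc(C(F)(F)F)cc(=O)[nH]2)n1` gives 150000 nM
compound 2 `Cc1cc(C)n(-c2nc(-c3ccc(F)cc3)cc(=O)[nH]2)n1` gives 4000 nM
compound 3 `Cc1cc(C)n(-c2nc(-c3cccnc3)cc(=O)[nH]2)n1` sits at a limit, > 50000 nM

Compound 2 holds the lowest of the two numbers in this assay. Its nearest neighbour is compound 1, with a 38-fold lower number from compound 1 to compound 2 (1.57 log units; beyond the scatter). Compound 3 is recorded only as a limit of this assay; that is the limit of > 50000 nM in this assay, at which 1 of the 3 values shown sits. Read against compound 2, this gives an at least 12-fold higher number from compound 2 to compound 3 (1.09 log units; beyond the scatter), and the step from compound 1 to compound 3 is a step that the limit leaves unreadable from compound 1 to compound 3.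

The next compound is compound 4 `Cc1cc(C)n(-c2nc(-c3ccc(NS(C)(=O)=O)cc3)cc(=O)[nH]2)n1`. It differs from compound 2 by methanesulfonamido in place of fluoro on an aromatic carbon. Within the data shown here, both measured steps swap the whole group on the core, never a substituent on the four-fluorophenyl ring, so no measured step matches this change directly. Among the measured compounds shown here, what the series shows is that compound 2, the only one carrying the four-fluorophenyl group, sits lowest, and that both other variants at that carbon give much higher numbers or a limit.

For compound 4 the number in this assay is expected to move up from compound 2 by a 5.0-fold higher number from compound 2 to compound 4 (0.70 log units; beyond the scatter), with a fair chance that only a limit is reported. The estimate for compound 4 is 20000 nM, with a range from 5000 nM to 80000 nM.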

Compound 4, half-maximal inhibitory concentration: > 50000 nM
Compound 4: a limit, no number; the forecaster's own chance of this, stated with the estimate: 30%; at least 2.5-fold (0.39 log units) between middle value and limit.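

Among these compounds, this is the first change made on the four-fluorophenyl ring itself rather than by swapping the whole group on the core, and it is not a neutral one: this assay gives an at least 12-fold higher number from compound 2 to compound 4 (1.09 log units; beyond the scatter). Keeping the phenyl ring on the core is therefore not enough to keep the low number of compound 2. Replacing fluoro with methanesulfonamido on that ring alone is enough to lose it. Compound 4 is recorded only as a limit and shares that limit with compound 3, so no order between these two compounds can be read and the full size of the step stays unknown: the limit of > 50000 nM in this assay, at which 2 of the 4 values shown sit.

The compounds shown leave open whether the low number of compound 2 depends on fluoro itself, which an unsubstituted phenyl ring or a chloro or methoxy group in the same place would test. They also leave open which part of methanesulfonamido carries the change, and an amino or acetamido group on that carbon would separate the nitrogen from the sulfonyl part.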